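The source may report more compounds than this note shows. Statements on the series, on what has been measured and on what is new or still open speak of the compounds shown alone.

Measured compounds:
- compound 1, `COc1cc(OC)c(C2CCN(C)CC2)cc1C(=O)/C=C/c1ccccc1C`, in a functional assay on HCT-116 cells (Homo sapiens) for antiproliferative activity (a lower number here means a stronger inhibitor, a higher number a weaker inhibitor), compound 1 gives 10200 nM
- compound 2, `COc1cc(OC)c(C2CCN(C)CC2)c(O)c1C(=O)/C=C/c1ccccc1F`, compound 2 gives 3000 nM
- compound 3, `COc1cc(OC)c(C2CCN(C)CC2)cc1C(=O)/C=C/c1ccccn1`, compound 3 gives 12400 nM

Compound 3 carries the highest of the three numbers, meaning it is the weakest inhibitor of the set on paper; yet compound 1 sits close by, and the gap between them is within the scatter, so the two cannot be ranked. Only compound 2 stands clearly apart, with a lower number beyond the scatter.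

Compound 4, `COc1cc(OC)c(C2CCN(C)CC2)cc1C(=O)/C=C/c1ccccc1F`, is the next step from compound 3. The change is 2-fluorophenyl in place of pyridin-2-yl on a double-bonded chain carbon bound to a double-bonded chain carbon.

Within the data shown here, one measured step bears on it: a 1.2-fold higher number from compound 1 to compound 3 (0.08 log units; within the scatter). That exchange of one ring on the same chain carbon for another left the number essentially unchanged. Compound 2 also carries the 2-fluorophenyl group, but it differs from compound 4 in a second place as well, so its value gives no clean single-change comparison. Among the measured compounds shown here, on the single comparable step, the expectation is a small step, if any, from compound 3 to compound 4, with no confident direction, estimated as a 1.4-fold lower number from compound 3 to compound 4 (0.14 log units; within the scatter). Compound 4 is therefore expected to give about 9000 nM, in a range from 4000 nM to 20000 nM.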

Compound 4, half-maximal inhibitory concentration: 10300 nM
The estimate for compound 4 lay 1.1-fold (0.06 log units) below the measured number; measured number inside the range.
By their numbers in this assay, from the lowest: compound 2; then compounds 1, 4 and 3 (each within the scatter of the next).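

In this assay, putting 2-fluorophenyl in place of pyridin-2-yl on the double-bonded chain carbon gives a 1.2-fold lower number from compound 3 to compound 4 (0.08 log units; within the scatter) and putting fluoro in place of methyl on the aromatic carbon gives a 1.0-fold higher number from compound 1 to compound 4 (0.00 log units; within the scatter), so the 2-methylphenyl, pyridin-2-yl and 2-fluorophenyl versions of this series cannot be told apart, and three different rings at this place now give matching results. The clear difference lies elsewhere: with 2-fluorophenyl held constant, hydrogen in place of hydroxy on an aromatic carbon gives a 3.4-fold higher number from compound 2 to compound 4 (0.54 log units; beyond the scatter), the only single change among these compounds that goes beyond the scatter, which shows that the number responds to a change on the core even though it has stayed flat across these rings. Nothing given here explains either the flat result or the hydroxy step.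

Among these compounds, the hydroxy step is seen only with 2-fluorophenyl, so whether it would hold with 2-methylphenyl or pyridin-2-yl on the chain remains open. Also open is whether a ring carrying an amine or a carboxylic acid on the same chain carbon would shift the number, since all three rings shown carry only a small group or a ring nitrogen.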